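From Fluorine to Chlorine on the Benzyl Group

A few compounds are considered here, and "the series" means these few. Any claim that something is new, unique, unknown or untested is made for them only; others in the source may bear on it.

Three measured compounds share one core and differ only in the group on the amide-type nitrogen. Compound 1 `O=C(Nc1ccccc1F)Nc1cc2ncncc2cc1OCc1cccc(F)c1` gives 8000 nM in a functional assay on GBM1 cells (Homo sapiens) for antiproliferative activity, read by WST assay, with a stated time of 72 h; on this read-out higher numbers stand for weaker inhibition and lower numbers for stronger inhibition; compound 2 `O=C(Nc1cc2ncncc2cc1OCc1cccc(F)c1)Nc1cccc2ccccc12` gives 1300 nM, the lowest of the three numbers; and compound 3 `O=C(Nc1ccc(C(F)(F)F)cc1)Nc1cc2ncncc2cc1OCc1cccc(F)c1` gives 3800 nM. Both steps, a 6.2-fold lower number from compound 1 to compound 2 (0.79 log units; beyond the scatter) and a 2.9-fold higher number from compound 2 to compound 3 (0.47 log units; beyond the scatter), were modest. Compound 4 `O=C(Nc1cc2ncncc2cc1OCc1ccccc1Cl)Nc1cccc2ccccc12` keeps the naphthalen-1-yl group of compound 2 and alters the other end: 2-chlorophenyl in place of 3-fluorophenyl on a saturated chain carbon bound to an oxygen on an aromatic ring. For the measured compounds named here, none of the measured steps touches this place, so they offer no direct guide; the unchanged remainder of the molecule argues for a number close to compound 2. For compound 4 the expected step is a 1.2-fold higher number from compound 2 to compound 4 (0.06 log units; within the scatter), within the scatter. Compound 4 is therefore estimated at 1500 nM, with a range from 500 nM to 4500 nM.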

Compound 4, half-maximal inhibitory concentration: 2900 nM
Compound 4: the middle estimate sits 1.9-fold (0.29 log units) below what was measured, within the range that was stated.
By their numbers in this assay, from the lowest: compound 2; then compounds 4 and 3 (each within the scatter of the next); then compound 1.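

Until now only the group on the amide-type nitrogen had varied; the other end of the molecule also affects the result. In this assay, placing 2-chlorophenyl where 3-fluorophenyl stood gives a 2.2-fold higher number from compound 2 to compound 4 (0.35 log units; beyond the scatter) and shows that this position responds to change, though modestly. Nothing available explains the shift. Still open, going by these compounds, is how much of the step comes from chlorine replacing fluorine and how much from where that atom sits on the ring. Also open, on these data alone, is how an amine or a carboxylic acid on this ring would fare.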